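This account rests on a few compounds, and the source may have more. Where it says the series, first, only, none or still open, it means among the compounds named here.

Compound 3, `CC(C)NC(=O)CC(c1ccc(-c2ccc3cccc(F)c3c2)[nH]c1=O)C(C)C`, is the reference for this step. Going by the values given here, in a functional assay on CHO cells for antagonist activity at prostaglandin E2 receptor EP3 subtype (Homo sapiens), read by cAMP accumulation (on this read-out lower numbers stand for stronger inhibition and higher numbers for weaker inhibition), compound 3 gives 15 nM, the lowest of the three numbers so far. Compound 1, `CC(C)C(c1ccc(-c2ccc3cccc(F)c3c2)[nH]c1=O)N1CCCCC1=O`, gives 40 nM in this assay, and compound 2, `CC(C)C(c1ccc(-c2ccc3cccc(F)c3c2)[nH]c1=O)N1CCN/C1=N\C#N`, gives 38 nM. The steps at the same saturated chain carbon were a 2.7-fold lower number from compound 1 to compound 3 (0.43 log units; beyond the scatter), a 2.5-fold lower number from compound 2 to compound 3 (0.40 log units; beyond the scatter) and a 1.1-fold lower number from compound 1 to compound 2 (0.02 log units; within the scatter).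

Compound 4, `Cc1c[nH]c(C(c2ccc(-c3ccc4cccc(F)c4c3)[nH]c2=O)C(C)C)n1`, carries 4-methyl-1H-imidazol-2-yl in place of (isopropylcarbamoyl)methyl on a saturated chain carbon bound to an aromatic carbon and a saturated chain carbon. The group that enters has one five-membered aromatic ring with 2 hetero atoms and keeps 1 hydrogen-bond donor and 1 hydrogen-bond acceptor, whereas the group that leaves has no ring. The two ring-bearing variants, compound 1 and compound 2, sat modestly higher than compound 3, so a modest step to a higher number in this assay is expected for compound 4, with nothing in the data pointing to more. Compound 4 is therefore estimated at 30 nM, with a range from 12 nM to 80 nM, which means an expected step of a 2.0-fold higher number from compound 3 to compound 4 (0.30 log units; within the scatter).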

Compound 4, half-maximal inhibitory concentration: 36 nM
Compound 4: middle estimate off by 1.2-fold (0.08 log units), on the low side; the measured number falls inside the stated range.
By their numbers in this assay, from the lowest: compound 3; then compounds 4, 2 and 1 (each within the scatter of the next).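

In this assay, placing an aromatic ring on this saturated chain carbon gives a 2.4-fold higher number from compound 3 to compound 4 (0.38 log units; beyond the scatter), so 4-methyl-1H-imidazol-2-yl joins the two non-aromatic ring-bearing groups on the higher side of the ring-free (isopropylcarbamoyl)methyl. The aromatic ring does not set itself apart from those groups, with a 1.1-fold lower number from compound 2 to compound 4 (0.02 log units; within the scatter) and a 1.1-fold lower number from compound 1 to compound 4 (0.05 log units; within the scatter), so among the three ring-bearing compounds this assay does not separate aromatic from non-aromatic rings. No measurement at hand accounts for the lower number of the ring-free compound 3.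

The compounds shown leave open whether that lower number extends to other ring-free groups at this carbon, such as a carboxylic acid, an amine or a longer chain. They also leave open what the methyl on the imidazole contributes, since the unsubstituted 1H-imidazol-2-yl group is not among them.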